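The source may hold more compounds than are shown below. What is called first, only, known or untested is meant among the compounds shown, and "the series" means these compounds.

Two compounds of the series have numbers in a functional assay on DU-145 cells (Homo sapiens) for cytotoxicity, read by trypan blue exclusion, with a stated time of 96 h (a higher number here means a weaker inhibitor, a lower number a stronger inhibitor), so far. Compound 1 `COc1cc(OC)c(/C=C/S(=O)(=O)Cc2ccc(Cl)cc2N)c(OC)c1` gives 2500 nM in this assay. Compound 2 `COC(=O)[C@H](C)Nc1cc(CS(=O)(=O)/C=C/c2c(OC)cc(OC)cc2OC)ccc1OC` gives 750 nM in this assay, the lowest of the two numbers, and its gap to compound 1 lies beyond the scatter. Compound 3 `COc1cc(OC)c(/C=C/S(=O)(=O)Cc2ccc(OC)c(NC(C(=O)O)c3ccc(F)cc3)c2)c(OC)c1` has not yet been measured in this assay. It differs from compound 2 in one place: carboxy(4-fluorophenyl)methyl in place of 1-(methoxycarbonyl)ethyl on a nitrogen on an aromatic ring. Going by the values given here, no step between measured compounds carries this change, so nothing measured bears on it directly; the expectation rests on compound 2 alone. The expected step in this assay is a 2.0-fold higher number from compound 2 to compound 3 (0.30 log units; within the scatter), toward a higher number, somewhat beyond the scatter but moderate in size, with a wide range to reflect the lack of a matching measured step. The estimate for compound 3 in this assay is 1500 nM, with a range from 400 nM to 6000 nM.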

Compound 3, half-maximal inhibitory concentration: 150 nM
Beside the measured number, compound 3's estimate is 10-fold (1.00 log units) above it; measured number below the stated range.
By their numbers in this assay, from the lowest: compound 3; then compound 2; then compound 1.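

At the nitrogen on an aromatic ring, this assay accepts a larger substituent without loss: carboxy(4-fluorophenyl)methyl in place of 1-(methoxycarbonyl)ethyl gives a 5.0-fold lower number from compound 2 to compound 3 (0.70 log units; beyond the scatter). The change brings in a carboxy group for the methyl ester and a six-membered aromatic ring together, so this single step cannot be divided between the two. Nothing at hand accounts for the step.

The compounds shown leave open whether the lower number follows the carboxy group, the 4-fluorophenyl ring or the two combined; a 1-carboxyethyl group and a methoxycarbonyl(4-fluorophenyl)methyl group on the same nitrogen would separate them. On these data alone, the part played by the fluorine also stays open, and a plain phenyl ring in its place would address it.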